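Series notes: the step from compound 3 to compound 4

A few compounds are considered here, and "the series" means these few. Any claim that something is new, unique, unknown or untested is made for them only; others in the source may bear on it.

Measured so far:
- compound 1 `CC(C)(C)c1cc(C(=O)NCCC2CCN(Cc3ccccc3)CC2)cc(C(C)(C)C)c1O`: in an assay on isolated protein for inhibition of Amine oxidase [flavin-containing] A (Homo sapiens), read by fluorescence, with stated times of 15 min and 20 min (on this read-out higher numbers stand for weaker inhibition and lower numbers for stronger inhibition), compound 1 gives 109000 nM
- compound 2 `COc1ccc(CN2CCC(CCNC(=O)/C=C/c3cc(C(C)(C)C)c(O)c(C(C)(C)C)c3)CC2)cc1`: compound 2 gives 72500 nM
- compound 3 `Cc1ccccc1CN1CCC(CCNC(=O)/C=C/c2cc(C(C)(C)C)c(O)c(C(C)(C)C)c2)CC1`: compound 3 gives 69300 nM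

Compound 3 holds the lowest of the three numbers, but only narrowly. For the measured compounds named here, the one counted step in the set, a 1.0-fold lower number from compound 2 to compound 3 (0.02 log units; within the scatter), swaps one aryl for another on the saturated chain carbon bound to the amine nitrogen in the ring and moves nothing beyond the scatter. Going by the values given here, compound 1, which carries a plain benzyl there and lacks the alkene of compounds 2 and 3, shows a number that sits within the scatter of compound 3 as well; no single-point step is counted between them.

Compound 4 `CC(C)(C)c1cc(/C=C/C(=O)NCCC2CCN(Cc3cccc(F)c3)CC2)cc(C(C)(C)C)c1O` is the next point in the same place: 3-fluorophenyl in place of 2-methylphenyl on a saturated chain carbon bound to an amine nitrogen in a ring. Among the compounds with values here, the only step that bears on it is the aryl swap from compound 2 to compound 3, which was flat. A step of the same kind is therefore expected to stay flat in this assay, with no direction beyond the scatter; the estimated step is a 1.0-fold higher number from compound 3 to compound 4 (0.00 log units; within the scatter).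

Compound 4 is thus expected to give about 70000 nM, with a range from 35000 nM to 140000 nM.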

Compound 4, half-maximal inhibitory concentration: 58400 nM
Compound 4: middle estimate off by 1.2-fold (0.08 log units), on the high side; measured number inside the range.
By their numbers in this assay, from the lowest: compounds 4, 3, 2 and 1 (each within the scatter of the next).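

In this assay the third aryl group at this place, 3-fluorophenyl on a saturated chain carbon bound to an amine nitrogen in a ring, gives a 1.2-fold lower number from compound 3 to compound 4 (0.07 log units; within the scatter) and likewise a 1.2-fold lower number from compound 2 to compound 4 (0.09 log units; within the scatter) as the second reading of it. Together with a 1.0-fold lower number from compound 2 to compound 3 (0.02 log units; within the scatter) as the earlier step, this puts 4-methoxyphenyl, 2-methylphenyl and 3-fluorophenyl all within the scatter of one another, so among compounds 2, 3 and 4 neither a fluorine on the aryl ring nor the exchange of methoxy, methyl and fluorine separates one compound from the others, and compound 4 at 58400 nM stays in the same range as its two neighbours. No supporting measurement bears on why these aryl swaps leave the number within the scatter.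

Still open, on these data alone, is whether any group at this place moves the number beyond the scatter, such as a benzyl carrying a carboxylic acid or an amine, or a longer chain in place of the benzyl. The compounds shown also leave open whether a change elsewhere in the shared core would do more than these aryl swaps have done in this assay here.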